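Swapping the acid-bearing ring on a weak kinase activator

The source may report more compounds than this note shows. Statements on the series, on what has been measured and on what is new or still open speak of the compounds shown alone.

Compound 3 `O=C(O)c1cncc(CN2CCC[C@H](OCc3cc(Cl)cc(Cl)c3)[C@@H]2c2ccccc2)c1` is one of three related compounds tested in an assay on isolated protein for activation of cGMP-dependent protein kinase 1 (Homo sapiens), read by ADP-Glo, with stated times of 120 min and 40 min; on this read-out higher numbers stand for an effect only at larger amounts of compound and lower numbers for an effect already at smaller amounts. Compound 3 gives 117000 nM, the highest of the two numbers recorded. Compound 1 `O=C(O)c1ccc(CN2CCC[C@H](OCc3cc(Cl)cc(Cl)c3)[C@@H]2c2ccccc2)s1` gives 76000 nM in this assay, and the gap a 1.5-fold higher number from compound 1 to compound 3 (0.19 log units; within the scatter) lies within the scatter. Compound 2 `CN1CCC[C@H](OCc2cc(Cl)cc(Cl)c2)[C@@H]1c1ccccc1` carries only hydrogen at that position and reaches only the limit of > 200000 nM in this assay, at which 1 of the 3 values shown sits, in this assay; compound 2 is recorded as > 200000 nM. Against that limit, the step of an at least 1.7-fold lower number from compound 2 to compound 3 (0.23 log units; that floor lies within the scatter) shows that an acid-bearing aromatic ring at this position brings a measurable number.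

Compound 4 `COc1cc(C(=O)O)ccc1CN1CCC[C@H](OCc2cc(Cl)cc(Cl)c2)[C@@H]1c1ccccc1` is not yet measured. It differs from compound 3 by 4-carboxy-2-methoxyphenyl in place of 5-carboxypyridin-3-yl on a saturated chain carbon bound to an amine nitrogen in a ring. Within the data shown here, the only comparable measured step, a 1.5-fold higher number from compound 1 to compound 3 (0.19 log units; within the scatter), exchanged one acid-bearing aromatic ring for another and stayed within the scatter, so for compound 4 a step of a 1.3-fold lower number from compound 3 to compound 4 (0.11 log units; within the scatter) in this assay is expected, that is, no shift beyond the scatter. The estimate for compound 4 is therefore 90000 nM, within 35000 nM to 250000 nM.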

Compound 4, half-maximal effective concentration: 62000 nM
Beside the measured number, compound 4's estimate is 1.5-fold (0.16 log units) above it, and the stated range covers the measured number.
By their numbers in this assay, from the lowest: compounds 4, 1 and 3 (each within the scatter of the next). At a limit, above all of these: compound 2.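

With 4-carboxy-2-methoxyphenyl, a second acid-bearing ring now clears the scatter against hydrogen at this position, alongside the 5-carboxythiophen-2-yl of compound 1: an at least 3.2-fold lower number from compound 2 to compound 4 (0.50 log units; beyond the scatter). A ring of carbon only that also carries a methoxy group cannot be told apart from the two rings with a hetero atom, with a 1.9-fold lower number from compound 3 to compound 4 (0.28 log units; within the scatter) and a 1.2-fold lower number from compound 1 to compound 4 (0.09 log units; within the scatter). Compound 2 is held at a limit of the assay and not at a number: the limit of > 200000 nM in this assay, at which 1 of the 4 values shown sits.

Going by these compounds, all three rings carry a carboxylic acid, so what a methyl ester or a primary amide would give in its place remains open. Also open, on these data alone, is what the methoxy group adds, which only a 4-carboxyphenyl ring without it could show.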